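Bromo-indazole amines: furan-2-yl to pyridin-4-yl at the chain carbon

The compounds below may be only part of what the source reports. "The series", "measured", "known", "first", "only" and "open" are said of these compounds alone.

Measured so far:
compound 1 `N#Cc1ccc(CNc2cc(Br)cc3[nH]ncc23)cc1` — 70%
compound 2 `Brc1cc(NCc2ccco2)c2cn[nH]c2c1` — 29%

Two compounds of this series have numbers in an assay for inhibition of Indoleamine 2,3-dioxygenase 1 (Homo sapiens), with a stated time of 1 h, tested at 10 uM; on this read-out higher numbers stand for more inhibition at the one concentration tested (going by the name of the read-out) and lower numbers for less inhibition. Compound 1 `N#Cc1ccc(CNc2cc(Br)cc3[nH]ncc23)cc1` gives 70% there. Compound 2 `Brc1cc(NCc2ccco2)c2cn[nH]c2c1` gives 29% in this assay, the lowest of the two numbers; the nearest is compound 1, whose number stands higher by a margin beyond the scatter. Among the measured compounds shown here, no single-point step between measured compounds is available, so the two values show only that the benzonitrile-bearing compound 1 sits well above compound 2.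

The next compound, compound 3 `Brc1cc(NCc2ccncc2)c2cn[nH]c2c1`, differs from compound 2 in one place: pyridin-4-yl in place of furan-2-yl on a saturated chain carbon bound to a nitrogen on an aromatic ring. For the measured compounds named here, with no measured step for this change, the expectation rests on the two numbers alone. Since compound 2 gives 29% and the series already reaches, with compound 1, 70%, a modest upward step in this assay is expected, possibly no larger than the scatter. The step from compound 2 to compound 3 is estimated as a number 11 percentage points higher from compound 2 to compound 3 (beyond the scatter). For compound 3 the expected value in this assay is 40%, within a range of 15% to 68%.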

Compound 3, a percentage reported as inhibition, at one concentration (the size of the read-out at that concentration, not a potency): 54%
The estimate for compound 3 lay 14 percentage points below the measured number; low and high end bracket the measured number.
By their numbers in this assay, from the lowest: compound 2; then compound 3; then compound 1.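

Among the compounds shown here, replacing furan-2-yl with pyridin-4-yl on a saturated chain carbon bound to a nitrogen on an aromatic ring gives a number 25 percentage points higher from compound 2 to compound 3 (beyond the scatter) in this assay, the first single-change reading, so the number at this position depends on the aromatic ring it carries. The two groups have the same counts of hetero atoms, hydrogen-bond donors and hydrogen-bond acceptors, so those counts do not separate them, while the change also replaces a five-membered aromatic ring with a six-membered one, and this single step cannot divide the difference between ring size and the identity of the hetero atom. No independent measurement bears on the origin of this step.

A plain phenyl ring would test whether the ring nitrogen of pyridin-4-yl matters, and pyridin-3-yl or thiophen-2-yl would help separate the hetero atom's identity and placement from ring size. A saturated piperidin-4-yl ring or a longer chain carrying the pyridine would show whether an aromatic ring and this chain length are needed for the reading seen with compound 3.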